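The source may report more compounds than this note shows. Statements on the series, on what has been measured and on what is new or still open speak of the compounds shown alone.

Measured in an ADME assay on microsomes from liver (Homo sapiens) for metabolic stability; a higher number here means that the compound lasts longer, a lower number that the compound disappears faster:

- Compound 1 `CC(C)C(c1cnc(N)s1)c1ccc(-c2ccc3cccc(F)c3c2)[nH]c1=O`: 0.178 h
- Compound 2 `CC(C)C(Cc1nnn[nH]1)c1ccc(-c2ccc3cccc(F)c3c2)[nH]c1=O`: > 3 h (a limit of the assay, not a number)

Compound 2 stands at the limit of > 3 h in this assay, at which 1 of the 2 values shown sits. Its exact half-life is therefore not known.

Among the compounds with values here, the next compound, compound 3 `CC(C)C(/C=C1\CCNC1=O)c1ccc(-c2ccc3cccc(F)c3c2)[nH]c1=O`, keeps the shared core and changes only one group, on a saturated chain carbon bound to an aromatic carbon and a saturated chain carbon. The change is a group of 7 heavy atoms (5 carbon, 1 nitrogen, 1 oxygen; one five-membered non-aromatic ring with 1 hetero atom) in place of a group of 6 heavy atoms (2 carbon, 4 nitrogen; one five-membered aromatic ring with 4 hetero atoms), on a saturated chain carbon bound to an aromatic carbon and a saturated chain carbon. The five-membered aromatic ring leaves, and a five-membered non-aromatic ring enters.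

Within the data shown here, one measured step bears on this, and it was made at the same place: an at least 16-fold higher number from compound 1 to compound 2 (1.22 log units; beyond the scatter). This large step shows that the group on this carbon can shift the half-life strongly. Compound 1, at 0.178 h, shows how low the half-life can fall with a different group there. A single step cannot show how this new group will behave, so the expectation remains loose. A modest fall is expected, and the estimated step is an at least 2.5-fold lower number from compound 2 to compound 3 (0.39 log units; beyond the scatter). For compound 3 the estimated half-life is 1.2 h, with an expected range of 0.3 h to 3 h.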

Compound 3, half-life: 0.713 h
Compound 3: the middle estimate sits 1.7-fold (0.23 log units) above what was measured; the range from low to high includes it.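

The group with the five-membered non-aromatic ring places compound 3 between the two earlier compounds in this assay: it lasts longer than with the 2-amino-1,3-thiazol-5-yl group (a 4.0-fold higher number from compound 1 to compound 3 (0.60 log units; beyond the scatter)) but falls short of the (1H-tetrazol-5-yl)methyl group (an at least 4.2-fold lower number from compound 2 to compound 3 (0.62 log units; beyond the scatter)). Both steps lie beyond the usual scatter, and compounds 1 and 2, each with an aromatic ring, stand on either side of compound 3, so in these three compounds the presence of an aromatic ring does not by itself set the order. For compound 2 the half-life is a limit of the assay and not a number, so the second step has only a lower bound: the limit of > 3 h in this assay, at which 1 of the 3 values shown sits.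

The compounds shown leave open how much of the half-life of compound 3 goes with its ring and how much goes with the double bonds outside aromatic rings that enter with it. As far as these compounds go, how a carboxylic acid, a simple amine or a longer chain on this saturated chain carbon would compare also remains open.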